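Swapping the chloromethyl arm for a pyrrolidine amide

The source may hold more compounds than are shown below. What is called first, only, known or untested is meant among the compounds shown, and "the series" means these compounds.

Compound 1 `CC(C)=CCC[C@]1(C)/C=C/[C@@H](OC(=O)C=C(C)C)[C@](C)(O)/C=C/C(=O)/C(CCl)=C\C1` is the reference point of this small set. In a functional assay on SMMC-7721 cells (Homo sapiens) for antiproliferative activity, read by MTT assay, with a stated time of 48 h (a lower number here means a stronger inhibitor, a higher number a weaker inhibitor), compound 1 gives 840 nM, the lowest of the two numbers available. Its nearest neighbour is compound 2 `CC(C)=CCC[C@]1(C)/C=C/[C@@H](OC(=O)C=C(C)C)[C@](C)(O)/C=C/C(=O)/C(CN=[N+]=[N-])=C\C1`, which in this assay gives 3080 nM. That step, a 3.7-fold higher number from compound 1 to compound 2 (0.56 log units; beyond the scatter), is a modest loss of potency. Compound 3 `CC(C)=CCC[C@]1(C)/C=C/[C@@H](OC(=O)C=C(C)C)[C@](C)(O)/C=C/[C@H](O)/C(CO)=C\C1` reaches only a limit of the assay rather than a number: in this assay compound 3 gives > 40000 nM. This is the limit of > 40000 nM in this assay, at which 1 of the 3 values shown sits.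

Compound 4 `CC(C)=CCC[C@]1(C)/C=C/[C@@H](OC(=O)C=C(C)C)[C@](C)(O)/C=C/C(=O)/C(C(=O)N2CCCC2)=C\C1` has not yet been measured. It differs from compound 1 by (pyrrolidin-1-yl)carbonyl in place of chloromethyl on a double-bonded ring carbon. Among the compounds with values here, the only measured step at the same place is the exchange of chloro for azido, which weakened the compound modestly. The change to compound 4 is larger, replacing the whole chloromethyl with a (pyrrolidin-1-yl)carbonyl, and a step of similar or somewhat greater size in the same direction, beyond the scatter, is expected. Compound 4 is therefore estimated at 3500 nM in this assay, with a range from 900 nM to 14000 nM. The implied step is expected to be a 4.2-fold higher number from compound 1 to compound 4 (0.62 log units; beyond the scatter).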

Compound 4, half-maximal inhibitory concentration: 14900 nM
Compound 4: middle estimate off by 4.3-fold (0.63 log units), on the low side; the measured number lies above the stated range.
By their numbers in this assay, from the lowest: compound 1; then compound 2; then compound 4. At a limit, above all of these: compound 3.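

In this assay, this position on a double-bonded ring carbon proves far more sensitive than the azido exchange alone could show: the (pyrrolidin-1-yl)carbonyl group gives an 18-fold higher number from compound 1 to compound 4 (1.25 log units; beyond the scatter) and this is a large loss of potency. The loss also holds against the already weaker azidomethyl arm, with a 4.8-fold higher number from compound 2 to compound 4 (0.68 log units; beyond the scatter) as a modest but clear further step, so the three arms fall in the order chloromethyl, azidomethyl, (pyrrolidin-1-yl)carbonyl, although compound 4 keeps a measurable antiproliferative effect. No measured property in the data shown accounts for the size of this change.

The exchange removes the chloromethyl arm and brings in a carbonyl and a five-membered ring together, so compound 4 alone cannot separate what each part contributes. On these data alone, it remains open how a carboxylic acid, a methyl ester or an aminomethyl arm at this place would compare, and these would show whether the loss follows the carbonyl, the pyrrolidine ring or simply the departure of the chlorine.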